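One Aromatic Group Exchanged on a Shared Core

The source may hold more compounds than are shown below. What is called first, only, known or untested is meant among the compounds shown, and "the series" means these compounds.

Of the compounds shown here, three built on one shared core have been tested in a functional assay on the whole organism (strain Swiss) with Mus musculus as the target, in the maximal electroshock model, with a stated time of 2 h, at a dose of 100 mg/kg by the intraperitoneal route; on this read-out lower numbers stand for a weaker effect and higher numbers for a stronger effect at the one dose given. Compound 1 `CC(C(=O)N1CCN(c2ccc(Cl)cc2)CC1)N1C(=O)CCC1=O` gives 0%. Compound 2 `CC(C(=O)N1CCN(c2ccc(F)cc2)CC1)N1C(=O)CCC1=O` gives 0%, and compound 3 `CC(C(=O)N1CCN(c2ccccc2C(F)(F)F)CC1)N1C(=O)CCC1=O` gives 0%. The step of no change at the digits printed from compound 1 to compound 2 (within the scatter) lies within the scatter, and compound 2 stands level with compounds 1 and 3 at the digits shown. Compound 4 `Cc1cccc(N2CCN(C(=O)C(C)N3C(=O)CCC3=O)CC2)c1` is not yet measured; it differs from compound 2 by 3-methylphenyl in place of 4-fluorophenyl on an amine nitrogen in a ring. Within the data shown here, the only measured step that bears on it is no change at the digits printed from compound 1 to compound 2 (within the scatter), which changed nothing. With no step beyond the scatter anywhere in the set, compound 4 is expected to stay where its neighbours lie, with an expected step of no change at the digits printed from compound 2 to compound 4 (within the scatter). The estimate for compound 4 is 0%, between 0% and 15%.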

Compound 4, a percentage reported as activity, at one dose (the size of the read-out at that dose, not a potency): 0%
For compound 4 middle estimate and measured number coincide at the digits printed; the measured number falls inside the stated range.
By their numbers in this assay, from the lowest: compounds 1, 2, 3 and 4 (each within the scatter of the next).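

In this assay the read-out shows no change at the digits printed from compound 2 to compound 4 (within the scatter) and no change at the digits printed from compound 1 to compound 4 (within the scatter). The level seen with the halogen-bearing groups therefore also holds for 3-methylphenyl, a group of carbon only, on the amine nitrogen in a ring. Nothing available explains this flat result. From the compounds shown here alone, whether any group at this place can raise the read-out remains open, for example a phenyl ring bearing an amine or a carboxylic acid. Equally open, going by these compounds, is whether these compounds would separate at another dose or time.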